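This account rests on a few compounds, and the source may have more. Where it says the series, first, only, none or still open, it means among the compounds named here.

In an ADME assay on the whole organism (plasma) for pharmacokinetics, with Rattus norvegicus as the target, with a stated time of 6 h, at a dose of 10 mg/kg by the oral route (on this read-out higher numbers stand for higher exposure at the dose given and lower numbers for lower exposure), compound 3 `CC1(COc2c(N3CCN(S(=O)(=O)Cc4cccc(N)c4)CC3)cnn(-c3cccc(Cl)c3)c2=O)CC1` gives 5700 ng.h/mL, level with compound 2 `Nc1cccc(CS(=O)(=O)N2CCN(c3cnn(-c4cc(F)cc(F)c4)c(=O)c3OC3CCCC3)CC2)c1` at 5700 ng.h/mL and within the scatter of compound 1 `Nc1ccc(CS(=O)(=O)N2CCN(c3cnn(-c4cc(F)cc(F)c4)c(=O)c3OC3CCCC3)CC2)cc1` at 8100 ng.h/mL. Compound 4 `CCc1cc(CS(=O)(=O)N2CCN(c3cnn(-c4cccc(Cl)c4)c(=O)c3OCC3(C)CC3)CC2)ccc1N` differs from compound 3 in one place, on a saturated chain carbon bound to a sulfonyl sulfur: 4-amino-3-ethylphenyl in place of 3-aminophenyl on a saturated chain carbon bound to a sulfonyl sulfur. Among the compounds with values here, only one measured step touches this group, a 1.4-fold lower number from compound 1 to compound 2 (0.15 log units; within the scatter), where 3-aminophenyl stands in place of 4-aminophenyl. Within the data shown here, no measured compound carries 4-amino-3-ethylphenyl, so the data give no direct test of this change. Among the measured compounds shown here, with that small step as the only guide, the expected change is a 1.0-fold lower number from compound 3 to compound 4 (0.02 log units; within the scatter), with no shift beyond the scatter anticipated. For compound 4 the estimate is 5500 ng.h/mL, with an expected range from 2200 ng.h/mL to 11000 ng.h/mL.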

Compound 4, area under the concentration-time curve: 9400 ng.h/mL
Compound 4: the middle estimate sits 1.7-fold (0.23 log units) below what was measured; the measured number falls inside the stated range.
By their numbers in this assay, from the lowest: compounds 2, 3, 1 and 4 (each within the scatter of the next).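

In this assay, a 1.6-fold higher number from compound 3 to compound 4 (0.22 log units; within the scatter) is what 4-amino-3-ethylphenyl gives in place of 3-aminophenyl, so on a saturated chain carbon bound to a sulfonyl sulfur the larger group, 9 heavy atoms against 7, costs no exposure beyond the scatter. This step alters the amino position and adds the ethyl at once, so it cannot separate the two. No measurement offered here explains the result. Still open, going by these compounds, is how a methyl or a longer chain in place of the ethyl would read, and whether the amine itself is needed, which a carboxylic acid in its place would test.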